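The source may hold more compounds than are shown below. What is called first, only, known or untested is meant among the compounds shown, and "the series" means these compounds.

Measured in a functional assay on DU-145 cells (Homo sapiens) for antiproliferative activity, read by MTT assay, with a stated time of 72 h; a lower number here means a stronger inhibitor, a higher number a weaker inhibitor:
Compound 1 `COc1cccc(N(C)S(=O)(=O)C2CC3OC2C(c2ccc(NC(=O)CCCCCCC(=O)O)cc2)=C3c2ccc(O)cc2)c1`: 62200 nM
Compound 2 `CN(c1ccccc1Cl)S(=O)(=O)C1CC2OC1C(c1ccc(NC(=O)CCCCCCC(=O)O)cc1)=C2c1ccc(O)cc1`: 73500 nM
Compound 3 `CCN(c1ccccc1)S(=O)(=O)C1CC2OC1C(c1ccc(NC(=O)CCCCCCC(=O)O)cc1)=C2c1ccc(O)cc1`: > 100000 nM

Compound 3 has a limit of the assay and no number, and it stands at the limit of > 100000 nM in this assay, at which 1 of the 3 values shown sits. Compound 4 `CCN(c1cccc(C)c1)S(=O)(=O)C1CC2OC1C(c1ccc(NC(=O)CCCCCCC(=O)O)cc1)=C2c1ccc(O)cc1` differs from compound 3 in one place: methyl in place of hydrogen on an aromatic carbon. Going by the values given here, no measured step makes this exact change. The closest are changes on the sulfonamide nitrogen, which gave a 1.2-fold higher number from compound 1 to compound 2 (0.07 log units; within the scatter), an at least 1.6-fold higher number from compound 1 to compound 3 (0.20 log units; that floor lies within the scatter) and an at least 1.3-fold higher number from compound 2 to compound 3 (0.13 log units; that floor lies within the scatter). All of these are small, so no step beyond the scatter is expected in this assay, and the expected result is an at least 1.1-fold lower number from compound 3 to compound 4 (0.04 log units; that floor lies within the scatter). For compound 4 the estimated value is 90000 nM, with an expected range of 45000 nM to 160000 nM.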

Compound 4, half-maximal inhibitory concentration: 65600 nM
Compound 4: the middle estimate sits 1.4-fold (0.14 log units) above what was measured, within the range that was stated.
By their numbers in this assay, from the lowest: compounds 1, 4 and 2 (each within the scatter of the next). At a limit, above all of these: compound 3.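

In this assay, putting a methyl on the aromatic ring of the ethyl(phenyl)amino group gives an at least 1.5-fold lower number from compound 3 to compound 4 (0.18 log units; that floor lies within the scatter). Compound 3 has only a limit, so this step is a floor and its full size cannot be read: the limit of > 100000 nM in this assay, at which 1 of the 4 values shown sits. The ethyl(3-methylphenyl)amino group also gives numbers within the scatter of the two methyl-bearing sulfonamides, with a 1.1-fold lower number from compound 2 to compound 4 (0.05 log units; within the scatter) and a 1.1-fold higher number from compound 1 to compound 4 (0.02 log units; within the scatter).

Still open, going by these compounds, is whether an amine on this aromatic ring, or a chain longer than ethyl on the sulfonamide nitrogen, would give a step beyond the scatter.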